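From Methylthiophene to Bromofuran on a Shared Core

The source may hold more compounds than are shown below. What is called first, only, known or untested is meant among the compounds shown, and "the series" means these compounds.

Measured in a functional assay on A549 cells (Homo sapiens) for cytotoxicity, read by MTT assay; a lower number here means a stronger inhibitor, a higher number a weaker inhibitor:
- compound 1 `COc1ccc(OC)c(C(=O)/C=C/c2ccsc2)c1`: 3800 nM
- compound 2 `COc1ccc(OC)c(C(=O)/C=C/c2ccc(C)s2)c1`: 4500 nM

Among the measured compounds shown here, only two compounds have been measured so far. Compound 2, at 4500 nM, stands within the scatter of compound 1, at 3800 nM, so neither can be ranked ahead of the other.

The next compound is compound 3 `COc1ccc(OC)c(C(=O)/C=C/c2occc2Br)c1`. It carries 3-bromofuran-2-yl in place of 5-methylthiophen-2-yl on a double-bonded chain carbon bound to a double-bonded chain carbon.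

For the measured compounds named here, one measured step bears on this change. The step of a 1.2-fold higher number from compound 1 to compound 2 (0.07 log units; within the scatter) exchanged one ring group for another at the same place, and it stayed within the scatter. Going by the values given here, that is thin evidence, since no measured compound carries 3-bromofuran-2-yl, and the range has to stay wide.

In this assay the expected result is a 1.1-fold lower number from compound 2 to compound 3 (0.05 log units; within the scatter), and no step beyond the scatter is expected in either direction. For compound 3 the estimated value is 4000 nM, with an expected range of 1500 nM to 10000 nM.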

Compound 3, half-maximal inhibitory concentration: 14900 nM
Beside the measured number, compound 3's estimate is 3.7-fold (0.57 log units) below it, and the stated range ends below it.
By their numbers in this assay, from the lowest: compounds 1 and 2 (each within the scatter of the next); then compound 3.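

In this assay, among the compounds shown here, this position proved sensitive to the choice of ring group for the first time: 3-bromofuran-2-yl in place of 5-methylthiophen-2-yl gives a 3.3-fold higher number from compound 2 to compound 3 (0.52 log units; beyond the scatter), whereas the earlier exchange of ring groups stayed within the scatter. The comparison with the other thiophene compound points the same way, with 3-bromofuran-2-yl in place of thiophen-3-yl giving a 3.9-fold higher number from compound 1 to compound 3 (0.59 log units; beyond the scatter), so the change is not tied to one thiophene partner, and it appears even though the leaving and entering groups match in heavy atoms, hetero atoms in the ring, hydrogen-bond donors and hydrogen-bond acceptors. Nothing measured alongside these numbers accounts for the shift.

The furan oxygen and the bromine enter together in compound 3, so the compounds shown do not separate their contributions, and a plain furan-2-yl or a 3-bromothiophen-2-yl at this place would be needed to do that. On these data alone, it also remains open how a ring group carrying an amine or a carboxylic acid would stand on the shared core in this assay.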